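The source may hold more compounds than are shown below. What is called first, only, known or untested is meant among the compounds shown, and "the series" means these compounds.

Measured in a functional assay on MCF7 cells (Homo sapiens) for inhibition, read by MTT assay, with a stated time of 72 h; a lower number here means a stronger inhibitor, a higher number a weaker inhibitor:
- compound 1 `Nc1ncnc2c1c(-c1cnc3[nH]ccc3c1)nn2CCCCCCCCC(=O)NO`: 24700 nM
- compound 2 `Nc1ncnc2c1c(-c1cnc3[nH]ccc3c1)nn2CCCCC(=O)NO`: > 150000 nM (a limit of the assay, not a number)
- compound 3 `Nc1ncnc2c1c(-c1cnc3[nH]ccc3c1)nn2CCCCCCC(=O)NO`: 19800 nM

Compound 3 stands at 19800 nM. Only compound 1 also has a real number, and a 1.2-fold lower number from compound 1 to compound 3 (0.10 log units; within the scatter) shows the two are level. Compound 2 gives only a limit, and an at least 7.5-fold lower number from compound 2 to compound 3 (0.87 log units; beyond the scatter) sets compound 3 clearly apart from it.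

Compound 4 `Nc1nc2cc(-c3nn(CCCCCCC(=O)NO)c4ncnc(N)c34)ccc2o1` keeps the chain of compound 3 and changes the aromatic group on the shared core: a group of 10 heavy atoms (7 carbon, 2 nitrogen, 1 oxygen; one five-membered aromatic ring with 2 hetero atoms, one six-membered aromatic ring of carbon only) in place of a group of 9 heavy atoms (7 carbon, 2 nitrogen; one five-membered aromatic ring with 1 hetero atom, one six-membered aromatic ring with 1 hetero atom), on an aromatic carbon. The group entering is 2-amino-1,3-benzoxazol-5-yl, on an aromatic carbon of the five-membered aromatic ring with 2 nitrogen.

Among the compounds with values here, none of the measured steps touches this group. All of them change the chain ending in hydroxycarbamoyl, including an at least 6.0-fold higher number from compound 1 to compound 2 (0.78 log units; beyond the scatter), so their sizes say nothing direct about the swap. Within the data shown here, the only anchor is compound 3 at 19800 nM, so no step beyond the scatter is expected, though with wide uncertainty in either direction. The expected change is a 1.3-fold lower number from compound 3 to compound 4 (0.12 log units; within the scatter).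

For compound 4 the estimated value in this assay is 15000 nM, with an expected range from 2500 nM to 60000 nM.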

Compound 4, half-maximal inhibitory concentration: 11900 nM
Compound 4: the middle estimate sits 1.3-fold (0.10 log units) above what was measured; measured number inside the range.
By their numbers in this assay, from the lowest: compounds 4, 3 and 1 (each within the scatter of the next, the first and the last beyond it). At a limit, above all of these: compound 2.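

Within the data shown here, every earlier step changed the chain ending in hydroxycarbamoyl, so this is the first look at the aromatic carbon of the five-membered aromatic ring with 2 nitrogen, and placing 2-amino-1,3-benzoxazol-5-yl there gives in this assay a 1.7-fold lower number from compound 3 to compound 4 (0.22 log units; within the scatter). A group with a different ring make-up, one more heavy atom and more hydrogen-bond acceptors therefore leaves the number level with that of the group it replaces, while the only steps shown beyond the scatter are those involving the chain of compound 2, whose value is a limit of the assay. Nothing measured here explains why this swap leaves the number level, since the only supporting fact concerns that limit and not the aromatic group.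

Going by these compounds, a single swap cannot show how far this level result extends, so it remains open whether a plain phenyl ring, or a ring carrying a carboxylic acid or a dimethylamino group, would also stay level at this position. Among these compounds, it is also open whether 2-amino-1,3-benzoxazol-5-yl would follow the same chain pattern as the earlier compounds if joined to a shorter or a longer chain.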